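The compounds below may be only part of what the source reports. "The series", "measured", "known", "first", "only" and "open" are said of these compounds alone.

Compound 2 `CC1CCN(C2CCN(S(=O)(=O)c3ccc(C#N)cc3)CC2)CC1` is the starting point for this step. Going by the values given here, in a functional assay on DLD-1 cells (Homo sapiens) for antiproliferative activity, read by CellTiter-Glo, with a stated time of 72 h (a lower number here means a stronger inhibitor, a higher number a weaker inhibitor), compound 2 gives 2800 nM, the only actual number among the values shown. Compound 1 `CC1CCN(C2CCN(S(=O)(=O)c3cccnc3Cl)CC2)CC1` is its closest measured relative. In this assay compound 1 reaches only a limit of the assay, > 5000 nM, and the limit of > 5000 nM in this assay, at which 1 of the 2 values shown sits, applies to it. Among the compounds with values here, the one measured step, an at least 1.7-fold lower number from compound 1 to compound 2 (0.25 log units; that floor lies within the scatter), came with the change of the group on the sulfonyl sulfur, and its floor lies within the scatter. Compound 3 `CC1CCN(C2CCN(S(=O)(=O)c3cccnc3)CC2)CC1` differs from compound 2 by pyridin-3-yl in place of 4-cyanophenyl on a sulfonyl sulfur. This change bears some resemblance to reversing the measured step, since the group that enters is again a pyridine on the sulfonyl sulfur, yet it is not the same group that compound 1 carried, so that step is only a rough guide. Compound 3 is therefore expected to show a 1.8-fold higher number from compound 2 to compound 3 (0.25 log units; within the scatter) in this assay, with a fair chance that only a limit is reported. The estimate for compound 3 is 5000 nM, within 2000 nM to 15000 nM.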

Compound 3, half-maximal inhibitory concentration: 2400 nM
Compound 3: middle estimate off by 2.1-fold (0.32 log units), on the high side; measured number inside the range.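

Going by these compounds alone, replacing the chloro on the pyridine ring with hydrogen gives an at least 2.0-fold lower number from compound 1 to compound 3 (0.31 log units; beyond the scatter) in this assay and is the first step to clear the scatter. Going by these compounds, compound 1 is held only at a limit of the assay, so the true size of that step stays unknown: the limit of > 5000 nM in this assay, at which 1 of the 3 values shown sits. Within the data shown here, replacing 4-cyanophenyl with pyridin-3-yl gives a 1.2-fold lower number from compound 2 to compound 3 (0.07 log units; within the scatter) and so leaves these two groups on the sulfonyl sulfur indistinguishable in this assay, which makes the chloro the only change here tied to a step beyond the scatter.

On these data alone, it remains open whether a phenyl ring carrying an amine or a carboxylic acid on the sulfonyl sulfur would give a number clearly apart from that of compound 3. The compounds shown also cannot tell whether a fluoro or a methyl in place of the chloro would match the step seen with hydrogen.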